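The source may report more compounds than this note shows. Statements on the series, on what has been measured and on what is new or still open speak of the compounds shown alone.

In a functional assay on NIH3T3 cells (Mus musculus) (a higher number here means that more compound is needed for the effect, a lower number that less compound is needed), three compounds sharing one core have been measured. Compound 1 (`Cn1cncc1C(OCc1ccc(C#N)cc1-c1cccc2ccccc12)c1ccc(C#N)nc1`), carrying naphthalen-1-yl, gives 46 nM as its half-maximal effective concentration. Compound 2 (`Cn1cncc1C(OCc1ccc(C#N)cc1-c1cccc(Cl)c1)c1ccc(C#N)nc1`), carrying 3-chlorophenyl, gives 2.1 nM and stands clearly apart, with a 22-fold lower number from compound 1 to compound 2 (1.34 log units; beyond the scatter) as the large step that leads to it. Compound 3 (`Cn1cncc1C(OCc1ccc(C#N)cc1-c1cc(F)cc(F)c1)c1ccc(C#N)nc1`), carrying 3,5-difluorophenyl, gives 25 nM and stays close to one neighbour, a 1.8-fold lower number from compound 1 to compound 3 (0.26 log units; within the scatter), but far from the other, a 12-fold higher number from compound 2 to compound 3 (1.08 log units; beyond the scatter).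

Compound 4 (`Cn1cncc1C(OCc1ccc(C#N)cc1-c1cccc(OC(F)(F)F)c1)c1ccc(C#N)nc1`) has no number yet, and its change is 3-(trifluoromethoxy)phenyl in place of 3,5-difluorophenyl on an aromatic carbon. The entering 3-(trifluoromethoxy)phenyl looks more like the 3-chlorophenyl of compound 2 than like 3,5-difluorophenyl, so the large step of a 12-fold higher number from compound 2 to compound 3 (1.08 log units; beyond the scatter) is the one that bears most. For the measured compounds named here, no measured compound carries trifluoromethoxy, so only part of that gap is expected to be recovered. In this assay a moderate move to a lower number is therefore expected, and the estimated step is a 3.1-fold lower number from compound 3 to compound 4 (0.49 log units; beyond the scatter). For compound 4 the expected value is 8 nM, with an estimated range from 2 nM to 30 nM.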

Compound 4, half-maximal effective concentration: 24 nM
Estimate against measurement, compound 4: 3.0-fold (0.48 log units) below; measured number inside the range.
By their numbers in this assay, from the lowest: compound 2; then compounds 4, 3 and 1 (each within the scatter of the next).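

In this assay the trifluoromethoxy swap leaves the number unchanged within the scatter (a 1.0-fold lower number from compound 3 to compound 4 (0.02 log units; within the scatter)), and compound 4 also sits within the scatter of the naphthalen-1-yl compound (a 1.9-fold lower number from compound 1 to compound 4 (0.28 log units; within the scatter)). For the compounds shown here, the new information lies in the single change from chloro to trifluoromethoxy on the same phenyl ring (an 11-fold higher number from compound 2 to compound 4 (1.06 log units; beyond the scatter)), which shows that the low number of compound 2 does not carry over to every group placed where its chloro sits, and compound 2 now stands alone, clearly apart from the other three. Nothing available here explains why chloro differs from trifluoromethoxy.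

Going by these compounds, whether this low number is special to chloro remains open. Bromo, methyl, methoxy or an amine in the same place on the phenyl ring would show how narrow the preference is.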